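A few compounds are considered here, and "the series" means these few. Any claim that something is new, unique, unknown or untested is made for them only; others in the source may bear on it.

Compound 1 `CC(C)[C@H](NC(=O)CN(c1nc(Cl)nc2[nH]cnc12)C1CC1)C(=O)OCc1ccccc1`: 11.8%
Compound 2 `N=C(N)NCCC[C@H](NC(=O)CN(c1nc(Cl)nc2[nH]cnc12)C1CC1)C(=O)O`: 12.1%

In a functional assay on the whole organism (Tail, strain ICR) with Mus musculus as the target, in the tail flick test, with a stated time of 90 min, at a dose of 6.25 umol/kg by the oral route (on this read-out higher numbers stand for a stronger effect at the one dose given and lower numbers for a weaker effect), compound 1 gives 11.8%, and in the same test compound 2 gives 12.1%. Compound 2 holds the higher of the two numbers, but the gap to compound 1 lies within the scatter of repeated measurements, so the two compounds cannot be told apart on this read-out, and neither may be called the more active.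

Compound 3 `NCCCC[C@H](NC(=O)CN(c1nc(Cl)nc2[nH]cnc12)C1CC1)C(=O)O` has not yet been measured in this assay. It differs from compound 2 as follows: a group of 2 heavy atoms (1 carbon, 1 nitrogen; no ring) in place of a group of 4 heavy atoms (1 carbon, 3 nitrogen; no ring), on a saturated chain carbon, four bonds along the chain from an amide-type nitrogen and a carbonyl carbon. Among the measured compounds shown here, no step between measured compounds is known in this set, so the size of the change cannot be read from a precedent. What the two measured compounds do show is that two rather different side chains give almost the same low value, which gives no ground to expect a move beyond the scatter in either direction. The step from compound 2 to compound 3 is therefore expected to be about a number 1.1 percentage points lower from compound 2 to compound 3 (within the scatter). For compound 3 in this assay the estimate is 11%, with a range from 3% to 22%.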

Compound 3, a percentage reported as activity, at one dose (the size of the read-out at that dose, not a potency): 14.5%
Compound 3: the middle estimate sits 3.5 percentage points below what was measured; the measured number falls inside the stated range.
By their numbers in this assay, from the lowest: compounds 1, 2 and 3 (each within the scatter of the next).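

In this assay, replacing the group of 4 heavy atoms (1 carbon, 3 nitrogen) with aminomethyl, on a saturated chain carbon four bonds along the chain from an amide-type nitrogen and a carbonyl carbon, gives a number 2.4 percentage points higher from compound 2 to compound 3 (within the scatter). Among the compounds shown here, this is the first step in the set that can be read at a single place, and it shows that this exchange, which removes a double bond outside aromatic rings and leaves fewer hydrogen-bond donors, does not separate compound 2 from compound 3 on this read-out at the one dose and time tested. No measurement accompanies the result that could explain it, and the reason for the similar values remains unknown.

From the compounds shown here alone, it remains open whether a carboxylic acid, a hydroxyl group or a longer chain ending in an amine at this position would give a step beyond the scatter. For the compounds shown here, with only this single exchange at one dose, the set also leaves open whether compound 2 and compound 3 would stay indistinguishable at other doses or times.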